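Swapping Iodo for Methyl in a Small Series

A few compounds are considered here, and "the series" means these few. Any claim that something is new, unique, unknown or untested is made for them only; others in the source may bear on it.

Of the compounds shown here, three sharing one core have been tested in a functional assay with Cavia porcellus as the target (a higher number here means that more compound is needed for the effect, a lower number that less compound is needed), and they differ at a single aromatic carbon. Compound 1 `COC(=O)c1c(C)[nH]c(C)c1C(=O)c1ccccc1Br`, which carries bromo there, gives 8950 nM. Compound 2 `COC(=O)c1c(C)[nH]c(C)c1C(=O)c1ccccc1`, which carries hydrogen, gives 21900 nM. Compound 3 `COC(=O)c1c(C)[nH]c(C)c1C(=O)c1ccccc1I`, which carries iodo, gives 5900 nM.

Compound 3 therefore stands level with the bromo member and clear of the hydrogen member. Swapping bromo for iodo gives a 1.5-fold lower number from compound 1 to compound 3 (0.18 log units; within the scatter), whereas swapping hydrogen for iodo gives a 3.7-fold lower number from compound 2 to compound 3 (0.57 log units; beyond the scatter).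

Compound 4 `COC(=O)c1c(C)[nH]c(C)c1C(=O)c1ccccc1C` has methyl in place of iodo on an aromatic carbon, ortho to a large group: methyl in place of iodo on an aromatic carbon. Going by the values given here, no measured step involves methyl, so the evidence is indirect. The closest guide is the removal of a halogen, where hydrogen in place of bromo gave a 2.4-fold higher number from compound 1 to compound 2 (0.39 log units; beyond the scatter). Both halogen compounds sit clear of the hydrogen compound, and methyl is neither. It is reasonable to expect the new compound to land inside the span of the series, somewhere between the iodo and hydrogen members. A small upward step is therefore expected: a 1.7-fold higher number from compound 3 to compound 4 (0.23 log units; within the scatter). Compound 4 is estimated at 10000 nM, with an expected range from 4000 nM to 25000 nM.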

Compound 4, half-maximal effective concentration: 9470 nM
Beside the measured number, compound 4's estimate is 1.1-fold (0.02 log units) above it, and the stated range covers the measured number.
By their numbers in this assay, from the lowest: compounds 3, 1 and 4 (each within the scatter of the next); then compound 2.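

Methyl on this aromatic carbon, ortho to a large group, gives much the same reading in this assay as the two halogens: replacing iodo gives a 1.6-fold higher number from compound 3 to compound 4 (0.21 log units; within the scatter) and replacing bromo gives a 1.1-fold higher number from compound 1 to compound 4 (0.02 log units; within the scatter) so neither swap moves the number past the usual scatter of repeated measurements. Methyl in place of hydrogen gives a 2.3-fold lower number from compound 2 to compound 4 (0.36 log units; beyond the scatter) and this shows that, among these compounds, a lower number than that of the hydrogen member does not depend on having a halogen at this position, since a one-carbon group does the same. No measured evidence here explains why methyl, bromo and iodo read alike, so the reason stays unknown.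

From the compounds shown here alone, all the groups compared here are single-atom or one-carbon substituents with no hydrogen-bond donors or acceptors, so it remains open how a methoxy group, an amine or a carboxylic acid would read at this position. Going by these compounds, a longer chain such as ethyl is equally open, as is whether methyl would give the same result on another carbon of the same ring.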